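The source may hold more compounds than are shown below. What is called first, only, known or untested is meant among the compounds shown, and "the series" means these compounds.

In a functional assay on PANC-1 cells (Homo sapiens) for cytotoxicity, read by WST assay, with a stated time of 24 h (a higher number here means a weaker inhibitor, a lower number a stronger inhibitor), compound 1 `O=C(CCCCCCCCCc1ccccc1)N1CCCCC1` gives > 100000 nM, which is a limit of the assay and not a number. Among the measured compounds shown here, compound 2 `O=C(CCCCCCCCc1ccccc1F)N1CCCCC1` gives 98900 nM, the only true number so far. Compound 3 `O=C(CCCCCCCCc1ccc(F)cc1)N1CCCCC1` has 4-fluorophenyl in place of 2-fluorophenyl, on a saturated chain carbon: 4-fluorophenyl in place of 2-fluorophenyl on a saturated chain carbon, eight bonds along the chain from a carbonyl carbon. For the measured compounds named here, the only measured step is a number no higher from compound 1 to compound 2 (the limit leaves the size open); it concerns a different exchange and offers no size to carry over. With no measured guide, the expected change is none beyond the scatter, which makes the estimated step of a 1.0-fold higher number from compound 2 to compound 3 (0.00 log units; within the scatter). Compound 3 is expected at 100000 nM, within an estimated range of 50000 nM to 200000 nM.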

Compound 3, half-maximal inhibitory concentration: 99800 nM
Beside the measured number, compound 3's estimate is 1.0-fold (0.00 log units) above it, and the stated range covers the measured number.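

In this assay, 4-fluorophenyl in place of 2-fluorophenyl, on a saturated chain carbon, eight bonds along the chain from a carbonyl carbon, gives a 1.0-fold higher number from compound 2 to compound 3 (0.00 log units; within the scatter). Among the compounds shown here, this is the first readable size for any change at this position, and it shows that this exchange leaves the number within the scatter. The other new step is a number no higher from compound 1 to compound 3 (the limit leaves the size open), and it cannot be read. Compound 1 stands at a limit of the assay and not a number: the limit of > 100000 nM in this assay, at which 1 of the 3 values shown sits.

The compounds shown leave open whether an amine or a carboxylic acid in place of the fluorine on this ring, or a shorter chain, would move the number beyond the scatter.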